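The source may hold more compounds than are shown below. What is called first, only, known or untested is meant among the compounds shown, and "the series" means these compounds.

Series notes. Among the measured compounds shown here, the shared core of compound 1 `O=C(Nc1ccc(Cl)c(-c2nnc3c(Cl)cccn23)c1)c1ccc(C(F)(F)F)cc1Cl` carries an amide whose carbonyl carbon bears a varied aryl group, and the three measured members differ only there. In a functional assay on A549 cells (Homo sapiens) for antiproliferative activity, read by MTT assay, with a stated time of 72 h (a higher number here means a weaker inhibitor, a lower number a stronger inhibitor), compound 1 gives > 100000 nM, which is a limit of the assay and not a number. Compound 2 `CS(=O)(=O)c1ccc(C(=O)Nc2ccc(Cl)c(-c3nnc4c(Cl)cccn34)c2)cc1` carries 4-(methylsulfonyl)phenyl on the carbonyl carbon; in this assay compound 2 gives > 100000 nM, again a limit. Compound 3 `Cc1cc(Cl)ccc1C(=O)Nc1ccc(Cl)c(-c2nnc3c(Cl)cccn23)c1` carries 4-chloro-2-methylphenyl; in this assay compound 3 gives > 100000 nM, also a limit. Compound 3 therefore stands at the same limit as the other two, and a step that the two limits leave unreadable from compound 2 to compound 3 cannot be read. All that is known of the measured steps is the limit of > 100000 nM in this assay, at which 3 of the 3 values shown sit.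

Compound 4 `O=C(Nc1ccc(Cl)c(-c2nnc3c(Cl)cccn23)c1)c1ccccc1Cl` is not yet measured. It differs from compound 3 by 2-chlorophenyl in place of 4-chloro-2-methylphenyl on a carbonyl carbon. For the measured compounds named here, no measured step reads on this change, since the one step available is unreadable. Compound 4 is expected to behave like compound 3, with an expected step of a number no higher from compound 3 to compound 4 (the limit leaves the size open). The estimate for compound 4 in this assay is 100000 nM, within 30000 nM to 300000 nM, and most likely the assay will again report only a limit.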

Compound 4, half-maximal inhibitory concentration: > 100000 nM
Compound 4: only a limit was reported; the forecaster's own chance of this, stated with the estimate: 85%; the middle value sits exactly at the limit.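

In this assay, among the compounds shown here, compound 4 gives > 100000 nM, a limit of the assay and not a number, so no step from compound 1, compound 2 or compound 3 to compound 4 can be read. The compounds shown leave open whether any aryl group on the carbonyl carbon gives a readable value in this assay, and how such groups would rank.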